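Fluoro for Chloro on a Benzylsulfanyl Arm: Expected Effect

This account rests on a few compounds, and the source may have more. Where it says the series, first, only, none or still open, it means among the compounds named here.

Of the compounds shown here, three have been tested in a functional assay on the whole organism (artery, strain albino) with Rattus norvegicus as the target, with a stated time of 30 min, at a dose of 10 mg/kg by the oral route; on this read-out higher numbers stand for more inhibition at the one dose given (going by the name of the read-out) and lower numbers for less inhibition. Compound 1 `COc1ccc(C2N=C(SCc3ccc(Cl)cc3)NC(C)=C2C(=O)Nc2ccc(Br)cc2)cc1` gives 7.2%, and compound 2 `COc1ccc(C2N=C(SCc3ccc(F)cc3)NC(C)=C2C(=O)Nc2ccc(Br)cc2)cc1`, in the same assay, gives 6.2%. Compound 2 differs from compound 1 by one change, (fluoro in place of chloro on an aromatic carbon), and this assay records a number 1 percentage points lower from compound 1 to compound 2 (within the scatter). Compound 3 `CC1=C(C(=O)Nc2ccc([N+](=O)[O-])cc2)C(c2cccc([N+](=O)[O-])c2)N=C(SCc2ccc(Cl)cc2)N1` rests on a core whose difference from the core of compound 1 is not broken down here. In this assay compound 3 gives 3.1%, a number within the scatter of both compound 1 and compound 2.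

Compound 4 `CC1=C(C(=O)Nc2ccc([N+](=O)[O-])cc2)C(c2cccc([N+](=O)[O-])c2)N=C(SCc2ccc(F)cc2)N1` has not been measured. It stands to compound 3 as compound 2 stands to compound 1: the difference is fluoro in place of chloro on an aromatic carbon, and the place of the change is the same. For the measured compounds named here, because a number 1 percentage points lower from compound 1 to compound 2 (within the scatter) is the one measured example of this change, the step is expected to be small in this assay: a number 0.6 percentage points lower from compound 3 to compound 4 (within the scatter). For compound 4 the expected value in this assay is 2.5%, with a range from -5% to 10%.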

Compound 4, a percentage reported as inhibition, in the whole organism at one dose (the size of the read-out at that dose, not a potency): 4.1%
Compound 4: middle estimate off by 1.6 percentage points, on the low side; measured number inside the range.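

Fluoro in place of chloro on the core of compound 3 gives, in this assay, a number 1 percentage points higher from compound 3 to compound 4 (within the scatter). Set beside the same change on the core of compound 1, the two steps do not differ: the same change on two cores in this assay, a number 1 percentage points lower (within the scatter) from compound 1 to compound 2 and a number 1 percentage points higher (within the scatter) from compound 3 to compound 4, 2 percentage points apart, within the scatter of two such steps This shows that, across these two pairs, the change carries from one core to the other with no step that stands out from the usual scatter, but it does not show that the change is without effect on other cores, and with both steps inside the scatter, the two pairs give it no direction.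

The compounds shown leave open how a group other than these two halogens would read at the same place on the benzylsulfanyl arm, for example a trifluoromethyl, an amine or a carboxylic acid. They also leave open whether the same swap would stay as small with a longer chain in place of the benzyl link to the sulfur.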